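Three inactive analogues and a fourth nitrile variant

The compounds below may be only part of what the source reports. "The series", "measured", "known", "first", "only" and "open" are said of these compounds alone.

Compound 1 `Cc1ccsc1C(c1c(C)noc1C)N1CCN(c2ncnc3c2cnn3-c2ccccc2)CC1` gives > 25000 nM in a functional assay on cells (Rhabdomyosarcoma cell, Homo sapiens) for cytotoxicity (on this read-out lower numbers stand for stronger inhibition and higher numbers for weaker inhibition), a limit of the assay rather than a number.
Compound 2 `c1ccc(C(c2ccco2)N2CCN(c3ncnc4c3cnn4-c3ccccc3)CC2)cc1` gives > 25000 nM in this assay, again a limit.
Compound 3 `N#Cc1cccc(C(c2ccccc2)N2CCN(c3ncnc4c3cnn4-c3ccccc3)CC2)c1` gives > 25000 nM in this assay, also a limit.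

Compound 2 thus stands at the limit of > 25000 nM in this assay, at which 3 of the 3 values shown sit; no number is known for it. Compound 4 `N#Cc1ccc(C(c2ccccc2)N2CCN(c3ncnc4c3cnn4-c3ccccc3)CC2)cc1` differs from it by 4-cyanophenyl in place of furan-2-yl on a saturated chain carbon bound to an amine nitrogen in a ring and an aromatic carbon. For the measured compounds named here, the only step that bears on this change, a step that the two limits leave unreadable from compound 2 to compound 3, is unreadable, since both ends are limits. The step that the limit leaves unreadable from compound 2 to compound 4 is therefore expected to stay unreadable in the same way. Compound 4 is estimated at 40000 nM in this assay, within 15000 nM to 150000 nM, most likely reported again as a limit.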

Compound 4, half-maximal inhibitory concentration: > 25000 nM
Compound 4: no number, only a limit; the forecaster's own chance of this, stated with the estimate: 85%; the middle value does not contradict the limit.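

Compound 4 also gives only a limit, so its steps from compound 2 and from compound 3 cannot be read. The compounds shown leave open whether swapping any of these groups changes the read-out in this assay at all.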